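The source may hold more compounds than are shown below. What is called first, only, known or untested is meant among the compounds shown, and "the series" means these compounds.

Measured compounds:
compound 1, `CC(C)=CC1C(C(=O)OCC2COCCOCCOCCOCCOCCO2)C1(C)C`, 40000 nM
compound 2, `O=C(CCCc1cc2ccccc2[nH]1)OCC1COCCOCCOCCOCCOCCO1`, > 100000 nM

In a functional assay on HBL-100 cells (Homo sapiens) for inhibition, read by sulforhodamine B assay, with a stated time of 48 h (on this read-out lower numbers stand for stronger inhibition of growth and higher numbers for weaker inhibition of growth), compound 1 gives 40000 nM. Compound 2 in this assay returns only a limit, > 100000 nM, not a number; this is the limit of > 100000 nM in this assay, at which 1 of the 2 values shown sits. No measured step between the two is given, so only the two values themselves are shown.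

Compound 3, `O=C(CCCCc1ccccc1)OCC1COCCOCCOCCOCCOCCO1`, differs from compound 2 by benzyl in place of 1H-indol-2-yl on a saturated chain carbon, three bonds along the chain from a carbonyl carbon. With compound 2 sitting at a limit, no direction can be read from the data. The expected step from compound 2 to compound 3 in this assay is a number no higher from compound 2 to compound 3 (the limit leaves the size open), nothing beyond the scatter. Compound 3 is estimated at 100000 nM, range 30000 nM to 300000 nM, most likely reported again as a limit.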

Compound 3, concentration for 50% growth inhibition: 69000 nM
Beside the measured number, compound 3's estimate is 1.4-fold (0.16 log units) above it; measured number inside the range.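

Benzyl in place of 1H-indol-2-yl on a saturated chain carbon, three bonds along the chain from a carbonyl carbon, gives an at least 1.4-fold lower number from compound 2 to compound 3 (0.16 log units; that floor lies within the scatter). Compound 2 returns only a limit, so the full size of this step stays unknown: the limit of > 100000 nM in this assay, at which 1 of the 3 values shown sits.

4-Phenylbutyl in place of 2,2-dimethyl-3-(2-methylprop-1-en-1-yl)cyclopropyl on a carbonyl carbon gives a 1.7-fold higher number from compound 1 to compound 3 (0.24 log units; within the scatter), so this exchange of very different groups has no effect that can be separated from the scatter.

Open, going by these compounds, is how an amine or a carboxylic acid at this chain carbon would read in this assay. A longer chain ending in phenyl is equally untested in the compounds shown.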